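Benzyl to oxan-3-yl on the aromatic oxygen

This account rests on a few compounds, and the source may have more. Where it says the series, first, only, none or still open, it means among the compounds named here.

Measured so far in a physicochemical assay for solubility, read by LC-MS, in phosphate buffer, measured as kinetic solubility, with a stated time of 24 h, at 25 degrees C, at pH 7.4; on this read-out higher numbers stand for higher solubility and lower numbers for lower solubility:
- compound 1 `CC(C)(C)Oc1cc(-c2ccnc(N)n2)cc2[nH]nc(N)c12` gives 68000 nM
- compound 2 `Nc1nccc(-c2cc(OCc3ccccc3)c3c(N)n[nH]c3c2)n1` gives 85000 nM
- compound 3 `Nc1nccc(-c2ccc3cn[nH]c3c2)n1` gives 215000 nM

Compound 2 lies within the scatter of compound 1. The value of compound 3 lies beyond the scatter of compound 2, on the higher side.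

Compound 4 `Nc1nccc(-c2cc(OC3CCCOC3)c3c(N)n[nH]c3c2)n1` has not yet been measured. It differs from compound 2 in one place, with oxan-3-yl in place of benzyl on an oxygen on an aromatic ring.

Within the data shown here, only one measured step changes a group at this place. Benzyl in place of tert-butyl gave a 1.3-fold higher number from compound 1 to compound 2 (0.10 log units; within the scatter). Among the measured compounds shown here, compound 3 differs from the others in more than one place, so it supplies no step for this comparison. For the measured compounds named here, no measured compound carries a non-aromatic ring with a hetero atom on this oxygen, so the evidence is thin.

On this single step, no shift beyond the scatter is expected in this assay. The expected step, slightly upward, is a 1.2-fold higher number from compound 2 to compound 4 (0.07 log units; within the scatter). For compound 4 the estimated value is 100000 nM, with an expected range from 50000 nM to 210000 nM.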

Compound 4, solubility: 1000000 nM
Estimate against measurement, compound 4: 10-fold (1.00 log units) below, outside the stated range (above it).
By their numbers in this assay, from the lowest: compounds 1 and 2 (each within the scatter of the next); then compound 3; then compound 4.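

In this assay, the group on this oxygen on an aromatic ring can move the number by a large margin, which the earlier pair did not show: benzyl in place of tert-butyl gave only a 1.3-fold higher number from compound 1 to compound 2 (0.10 log units; within the scatter) and stayed within the scatter, whereas oxan-3-yl in place of benzyl gives a 12-fold higher number from compound 2 to compound 4 (1.07 log units; beyond the scatter) and oxan-3-yl in place of tert-butyl gives a 15-fold higher number from compound 1 to compound 4 (1.17 log units; beyond the scatter) in the same series. Both large steps end at compound 4, the only compound shown with a non-aromatic ring with a hetero atom on this oxygen, so they rest on this single group, and benzyl and tert-butyl remain within the scatter of each other. No measurement available here accounts for the size of these steps.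

Going by these compounds, it remains open whether the step follows the oxygen of the oxan-3-yl ring or the departure of the aromatic ring of benzyl, and a cyclohexyl group on this oxygen would separate the two. A piperidin-4-yl group, with an amine in the ring, would show whether a different hetero atom at this place gives a step of similar size.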